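The compounds below may be only part of what the source reports. "The series", "measured", "known", "first", "only" and "open" are said of these compounds alone.

Compound 1 `Oc1cccc(CNCc2ccncc2)c1`: in an ADME assay on HEK293 cells for antagonist activity at solute carrier family 2, facilitated glucose transporter member 8 (Homo sapiens), with stated times of 5 min and 6 min (on this read-out lower numbers stand for stronger inhibition and higher numbers for weaker inhibition), compound 1 gives > 100000 nM, a limit of the assay and not a number.
Compound 2 `COc1ccc(C(=O)N(Cc2ccncc2)Cc2cccc(OCc3cccc(OC)c3)c2)cc1`: in this assay compound 2 gives > 100000 nM, likewise a limit and not a number.

Compound 2 thus stands at the limit of > 100000 nM in this assay, at which 2 of the 2 values shown sit, with no number on either side to place it against. Compound 3 `COc1ccc(C(=O)N(Cc2ccncc2)Cc2cccc(OCCc3ccc(F)cc3)c2)cc1` differs from compound 2 by 4-fluorobenzyl in place of 3-methoxyphenyl on a saturated chain carbon bound to an oxygen on an aromatic ring. Among the measured compounds shown here, no measured step bears on this change. In this assay the expected step is a number no higher from compound 2 to compound 3 (the limit leaves the size open), none beyond the scatter. Compound 3 is therefore estimated at 100000 nM, range 30000 nM to 300000 nM, most likely again reported only as a limit.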

Compound 3, half-maximal inhibitory concentration: 6000 nM
The estimate for compound 3 lay 17-fold (1.22 log units) above the measured number; measured number below the stated range.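

In this assay the change on a saturated chain carbon bound to an oxygen on an aromatic ring gives the only number among the compounds shown, with an at least 16-fold lower number from compound 2 to compound 3 (1.22 log units; beyond the scatter). This position therefore responds to substitution: 2-(4-fluorophenyl)ethoxy in place of (3-methoxybenzyl)oxy moves compound 3 off the limit, where the other compounds remain: the limit of > 100000 nM in this assay, at which 2 of the 3 values shown sit.

The compounds shown do not separate the fluorine, the longer link and the loss of the methoxy group from one another. Also open, going by these compounds, is how an amine, a carboxylic acid or a still longer chain at this position would read in this assay.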